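A few compounds are considered here, and "the series" means these few. Any claim that something is new, unique, unknown or untested is made for them only; others in the source may bear on it.

Measured in a physicochemical assay for lipophilicity, read by HPLC, in phosphate buffer, measured as octanol-water partition, at pH 7.4, tested at 100 uM; a lower number here means a more polar compound, a higher number a more lipophilic compound:
- Compound 1 `O=C(O)COc1ccc(NCc2cccc(-c3ccccc3F)c2)cc1F`: 2.36
- Compound 2 `O=C(O)COc1ccc(NCc2cccc(-c3ccccc3Cl)c2)cc1F`: 2.71
- Compound 3 `Cc1ccccc1-c1cccc(CNc2ccc(OCC(=O)O)c(F)c2)c1`: 2.41

Compound 3 cannot be told apart from the other two: the gaps are a number 0.05 log units higher from compound 1 to compound 3 (within the scatter) and a number 0.30 log units lower from compound 2 to compound 3 (within the scatter). Compound 4 `CC(C)c1ccccc1-c1cccc(CNc2ccc(OCC(=O)O)c(F)c2)c1` changes the same aromatic carbon, with isopropyl in place of methyl, 2-methylphenyl to 2-isopropylphenyl (isopropyl in place of methyl on an aromatic carbon). For the measured compounds named here, no measured step makes this exact swap, so the guide is loose. Going by the values given here, the one step beyond the scatter is a number 0.35 log units higher from compound 1 to compound 2 (beyond the scatter). Taking that as a yardstick, and with more carbon entering here, a modest upward move is expected in this assay. The estimated change is a number 0.44 log units higher from compound 3 to compound 4 (beyond the scatter). For compound 4 the expected value is 2.85, with an estimated range of 2.5 to 3.2.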

Compound 4, distribution coefficient: 3.45
Beside the measured number, compound 4's estimate is 0.60 log units below it; the whole stated range lies below it.
By their numbers in this assay, from the lowest: compounds 1, 3 and 2 (each within the scatter of the next, the first and the last beyond it); then compound 4.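

In this assay this aromatic carbon, ortho to a large group, proves able to shift the number much further than the earlier swaps suggested: a number 1.04 log units higher from compound 3 to compound 4 (beyond the scatter) and a number 1.09 log units higher from compound 1 to compound 4 (beyond the scatter) and also a number 0.74 log units higher from compound 2 to compound 4 (beyond the scatter) are all beyond the scatter. Isopropyl therefore stands clear of fluoro, chloro and methyl at this carbon. Nothing measured here accounts for the size of the jump.

These compounds cannot separate the added carbons from the branching. A straight propyl chain, a tert-butyl group or an amine at this carbon remains an open comparison.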